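This account rests on a few compounds, and the source may have more. Where it says the series, first, only, none or still open, it means among the compounds named here.

Measured so far in a functional assay (spleen, spleen) for activation, with Mus musculus as the target; on this read-out lower numbers stand for an effect already at smaller amounts and higher numbers for an effect only at larger amounts of compound:
compound 1, `CCNc1nc(N)c2nc(O)n(Cc3ccccc3)c2n1`: 1 uM
compound 2, `Nc1ncnc2c1nc(O)n2C1CCCC1`: > 10 uM
compound 3, `COc1cccc(Cn2c(O)nc3c(N)ncnc32)c1`: 10 uM

Compound 1 holds the lowest of the two numbers shown in this assay; its nearest neighbour, compound 3, gives a higher number, beyond the scatter. Compound 2 reports no number but only a limit of the assay, (the limit of > 10 uM in this assay, at which 1 of the 3 values shown sits).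

The unmeasured compound 4, `CCCCCSc1nc(N)c2nc(O)n(Cc3ccccc3)c2n1`, differs from compound 1 by pentylsulfanyl in place of ethylamino on an aromatic carbon. Going by the values given here, no step between measured compounds matches this change. In this assay a modest gain is expected, or none beyond the scatter: the step is estimated as a 2.0-fold lower number from compound 1 to compound 4 (0.30 log units; within the scatter). Compound 4 is therefore expected to give 0.5 uM, within a range from 0.05 uM to 5 uM.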

Compound 4, minimum effective concentration: 10 uM
Estimate against measurement, compound 4: 20-fold (1.30 log units) below, and the stated range ends below it.
By their numbers in this assay, from the lowest: compound 1; then compounds 3 and 4 (each within the scatter of the next).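

In this assay, pentylsulfanyl in place of ethylamino on the aromatic carbon between two ring nitrogen atoms gives a 10-fold higher number from compound 1 to compound 4 (1.00 log units; beyond the scatter). This shows that the read-out responds to the group at this position, and that this exchange moves it in the unfavourable direction, beyond the scatter. Nothing shown accounts for the size of this step.

The compounds shown leave open whether the step follows the sulfur link or the longer chain. A pentylamino or an ethylsulfanyl group at this position would separate the two.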